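The source may report more compounds than this note shows. Statements on the series, on what has been measured and on what is new or still open speak of the compounds shown alone.

In a functional assay on SW 1116 cells (Homo sapiens) for antiproliferative activity, read by MTT assay, with a stated time of 48 h (on this read-out higher numbers stand for weaker inhibition and lower numbers for stronger inhibition), compound 1 `Fc1ccc(CSc2nnc(-c3ccc4c(c3)OCCO4)o2)cc1` gives 21600 nM while compound 2 `Brc1ccccc1CSc1nnc(-c2ccc3c(c2)OCCO3)o1` gives 14100 nM and compound 3 `Clc1ccc(CSc2nnc(-c3ccc4c(c3)OCCO4)o2)cc1` gives 28400 nM so compound 3 lies within the scatter of both others. Compound 4 `Clc1ccccc1CSc1nnc(-c2ccc3c(c2)OCCO3)o1` carries 2-chlorophenyl in place of 4-chlorophenyl on a saturated chain carbon bound to a sulfur. Within the data shown here, two measured steps bear on this change. The step of a 1.3-fold higher number from compound 1 to compound 3 (0.12 log units; within the scatter) exchanged chloro for fluoro, and the step of a 2.0-fold higher number from compound 2 to compound 3 (0.30 log units; within the scatter) replaced 2-bromophenyl with 4-chlorophenyl. Both stayed within the scatter. Neither tests this exact change, but no shift beyond the scatter is expected in this assay here. Among the measured compounds shown here, the estimate leans slightly toward compound 2 (14100 nM) as the only measured compound with a group at the 2 position of its phenyl. The expected step is a 1.5-fold lower number from compound 3 to compound 4 (0.17 log units; within the scatter) and would stay within the scatter. Compound 4 is expected near 19000 nM with an estimated range from 9000 nM to 38000 nM on this read-out.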

Compound 4, half-maximal inhibitory concentration: 29500 nM
For compound 4 the middle estimate is 1.6-fold (0.19 log units) below the measured one; low and high end bracket the measured number.
By their numbers in this assay, from the lowest: compounds 2, 1, 3 and 4 (each within the scatter of the next, the first and the last beyond it).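

Going from 4-chlorophenyl to 2-chlorophenyl on the same chain carbon, the first direct test of where the chlorine sits, gives a 1.0-fold higher number from compound 3 to compound 4 (0.02 log units; within the scatter) in this assay, so the two placements cannot be told apart here. Chloro in place of bromo gives a 2.1-fold higher number from compound 2 to compound 4 (0.32 log units; beyond the scatter), a modest step and the only one in this set beyond the scatter, while 2-chlorophenyl in place of 4-fluorophenyl gives a 1.4-fold higher number from compound 1 to compound 4 (0.14 log units; within the scatter). No evidence here explains these steps.

All four compounds carry a halogen on the phenyl ring. From the compounds shown here alone, whether an amine or a carboxylic acid there, or a longer chain to the sulfur, would shift the number remains open.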